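This account rests on a few compounds, and the source may have more. Where it says the series, first, only, none or still open, it means among the compounds named here.

Compound 1 `COC(=O)c1ccc(-c2nnn(CC(=O)C(C)Oc3ccc(-c4ccccc4)cc3)n2)cc1` gives 21% in an ADME assay on S9 fraction from liver (Rattus norvegicus) for metabolic stability, read by LC-MS, using NADPH, with a stated time of 30 min; a lower number here means that less of the compound is left, a higher number that more of the compound is left.
Compound 2 `CC(Oc1ccc(Oc2ccc(Cl)cc2)cc1)C(=O)Cn1nnc(-c2ccc(C(=O)O)cc2)n1` gives 32% in this assay.

Within the data shown here, of the two compounds measured so far, compound 2 stands highest in this assay, and the gap to compound 1 lies beyond the usual scatter of this measurement. Compound 3 `CC(Oc1ccc(-c2ccccc2)cc1)C(=O)Cn1nnc(-c2ccc(C(=O)O)cc2)n1` has not yet been measured. It differs from compound 2 in one place: phenyl in place of 4-chlorophenoxy on an aromatic carbon. The phenyl group that enters is the same group that compound 1 carries, and in this assay compound 1 gives 21%, though compound 1 also differs from compound 3 elsewhere, so no single step can be read from the pair. For the change from compound 2 to compound 3 a small step downwards, or none beyond the scatter, is expected. For compound 3 the value in this assay is estimated at 25%, within a range from 12% to 40%, meaning an expected step of a number 7 percentage points lower from compound 2 to compound 3 (within the scatter).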

Compound 3, percent of the compound remaining in the Rattus norvegicus assay: 30%
For compound 3 the middle estimate is 5 percentage points below the measured one, and the stated range covers the measured number.
By their numbers in the Rattus norvegicus assay, from the lowest: compounds 1, 3 and 2 (each within the scatter of the next, the first and the last beyond it).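

In the Rattus norvegicus assay, phenyl in place of 4-chlorophenoxy gives a number 2 percentage points lower from compound 2 to compound 3 (within the scatter), so at this position, on an aromatic carbon para to a large group, the swap makes no difference that can be told from scatter. A change elsewhere in the molecule, hydrogen in place of methyl on an oxygen next to a carbonyl group, likewise stays inside the scatter, with a number 9 percentage points higher from compound 1 to compound 3 (within the scatter). Yet a physicochemical assay for lipophilicity, read by HPLC, tested at 5 mM (on this read-out lower numbers stand for lower lipophilicity and higher numbers for higher lipophilicity), does separate these two phenyl and 4-chlorophenoxy compounds, so a clear drop in lipophilicity here comes without a clear change in the compound remaining: the measured partition coefficient of compound 2, 3.3, and of compound 3, 2.6, a number 0.70 log units lower (beyond the scatter). In the physicochemical assay compound 2 gives 3.3 and compound 3 gives 2.6.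

Still open, as far as these compounds go, is whether a different group at this position, such as an amine or a longer chain, would shift the amount left. Also open, from the compounds shown here alone, is whether an amide on that carbonyl group would give the same picture.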